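Extending the benzylic amine in a melanocortin receptor 4 series

This account rests on a few compounds, and the source may have more. Where it says the series, first, only, none or still open, it means among the compounds named here.

Measured compounds:
- compound 1 `CCC(C)C(N)c1cc(C(F)(F)F)ccc1N1CCN(C(=O)CCc2ccc(Cl)cc2Cl)CC1`: 160 nM
- compound 2 `COc1ccc(CCC(=O)N2CCN(c3ccc(C(F)(F)F)cc3[C@@H](N)CC(C)C)CC2)cc1`: 350 nM

In an assay on HEK293 cells for displacement of a labelled ligand from Melanocortin receptor 4 (Homo sapiens) (a higher number here means a weaker inhibitor, a lower number a stronger inhibitor), compound 1 gives 160 nM, the lower of the two numbers; compound 2, measured in this assay, gives 350 nM, and the gap between the two lies beyond the scatter of repeated measurements. Among the measured compounds shown here, compound 2 also carries a different acyl part and a defined stereocentre, so the two values show only that compound 1 stands as the stronger inhibitor of the pair.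

Compound 3 `CCC(C)[C@H](NCCN)c1cc(C(F)(F)F)ccc1N1CCN(C(=O)CCc2ccc(Cl)cc2Cl)CC1` is the unmeasured analogue of compound 1. It differs in one place: 1-((2-aminoethyl)amino)-2-methylbutyl in place of 1-amino-2-methylbutyl on an aromatic carbon. For the measured compounds named here, no measured pair in the set isolates this change, so nothing here calibrates its size. The shared core and the acyl part stay as in compound 1, and the change touches only the substituent ortho to the large group. For compound 3 the step from compound 1 is expected to be small, a 1.3-fold lower number from compound 1 to compound 3 (0.12 log units; within the scatter), with no firm direction beyond the scatter. Compound 3 is therefore estimated at 120 nM in this assay, within a range of 40 nM to 400 nM.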

Compound 3, inhibition constant: 56 nM
Estimate against measurement, compound 3: 2.1-fold (0.33 log units) above; the range from low to high includes it.
By their numbers in this assay, from the lowest: compound 3; then compound 1; then compound 2.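

The amine carbon on this aromatic carbon, ortho to a large group, accepts extension in this assay: the step to 1-((2-aminoethyl)amino)-2-methylbutyl is a 2.9-fold lower number from compound 1 to compound 3 (0.46 log units; beyond the scatter) and brings a lower number rather than a loss. Among the compounds shown here, this is the only reading of a change at this position, and it holds with the shared core and the acyl part kept as in compound 1, but the entering group also has a defined stereocentre, so the added chain and that stereocentre are read together. Nothing available explains the step.

Open, from the compounds shown here alone, is whether the number depends on the terminal amine or on the chain itself, which a terminal hydroxyl or a longer aminopropyl chain would test. Also open, going by these compounds, is whether the same extension holds with the acyl part of compound 2.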